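The compounds below may be only part of what the source reports. "The series", "measured", "known", "first", "only" and "open" are said of these compounds alone.

Working notes on the series.

Compound 1, `Cc1cc(C)nc(Sc2ccc(NC(=O)Nc3ccccc3)cc2)n1`, is the parent of the series. In a functional assay on MCF7 cells (Homo sapiens) for cytotoxicity, read by MTT assay, with a stated time of 3 days (a higher number here means a weaker inhibitor, a lower number a stronger inhibitor), compound 1 gives > 50000 nM, which is a limit of the assay rather than a measured number. Compound 2, `Cc1cc(C)nc(Sc2ccc(NC(=O)Nc3ccc(F)cc3)cc2)n1`, carries a fluoro on an aromatic carbon where compound 1 has hydrogen. In this assay compound 2 gives > 50000 nM, again a limit of the assay and not a number. The step from compound 1 to compound 2 is therefore a step that the two limits leave unreadable from compound 1 to compound 2. Both values sit on (the limit of > 50000 nM in this assay, at which 2 of the 2 values shown sit), so nothing can be said about the size or direction of that step.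

Compound 3, `Cc1cc(C)nc(Sc2ccc(NC(=O)Nc3ccc(Cl)cc3)cc2)n1`, differs from compound 2 by chloro in place of fluoro on an aromatic carbon. Among the measured compounds shown here, the only measured step that bears on it is the one from compound 1 to compound 2, which is unreadable, so no expectation of a step beyond the scatter can be drawn from it. Compound 3 is therefore expected to stand at or near the limit as well, estimated in this assay at 60000 nM, within 20000 nM to 200000 nM. The step from compound 2 to compound 3 is estimated as a step that the limit leaves unreadable from compound 2 to compound 3.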

Compound 3, half-maximal inhibitory concentration: 35300 nM
Compound 3: middle estimate off by 1.7-fold (0.23 log units), on the high side, within the range that was stated.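

Among the compounds shown here, compound 3 is the first compound to give a measured number in this assay rather than a limit of the assay, so this position, on the aromatic carbon para to a large group, now has one readable point. Chloro in place of fluoro gives an at least 1.4-fold lower number from compound 2 to compound 3 (0.15 log units; that floor lies within the scatter), and chloro in place of hydrogen gives an at least 1.4-fold lower number from compound 1 to compound 3 (0.15 log units; that floor lies within the scatter). Both floors lie within the scatter, so the change from either neighbour is not shown to be real, and only a floor can be stated for each step because the values of compound 1 and compound 2 are limits of the assay: the limit of > 50000 nM in this assay, at which 2 of the 3 values shown sit.

On these data alone, the true size of both steps stays open, and with it whether chloro differs at all from fluoro or hydrogen at this position. The compounds shown also leave open how a bromo, methoxy or trifluoromethyl group on the same carbon would read, and whether an amine or a carboxylic acid there would move the number clearly beyond the scatter.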